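Larger Ring Replaces Methyl: Expected Solubility of Compound 4

A few compounds are considered here, and "the series" means these few. Any claim that something is new, unique, unknown or untested is made for them only; others in the source may bear on it.

The measured compounds:
- compound 1, `COC(c1cc(Cl)c2c(c1Cl)C(=O)N(Cc1c(C)cc(C)[nH]c1=O)CC2)C1CCN(C(C)=O)CC1`, 532000 nM; 498000 nM (2 entries)
- compound 2, `Cc1cc(C)c(CN2CCc3c(Cl)cc([C@@H](C)CO)c(Cl)c3C2=O)c(=O)[nH]1`, 143000 nM
- compound 3, `COc1cc(C)[nH]c(=O)c1CN1CCc2c(Cl)cc([C@H](O)C3COC3)c(Cl)c2C1=O`, 234000 nM

Of the compounds shown here, three sharing the same core have been tested in a physicochemical assay for solubility, measured as kinetic solubility; on this read-out lower numbers stand for lower solubility and higher numbers for higher solubility. Compound 1 was run twice, and its two entries are given by the several entries of compound 1 in this assay, 532000 nM; 498000 nM (2 entries). Compound 2 has the lowest single number among the compounds with one value; its nearest neighbour is compound 3, whose value lies within the scatter of the measurement, so no order between compound 2 and compound 3 can be read from these figures.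

Compound 4, `Cc1cc(C)c(CN2CCc3c(Cl)cc([C@H](CO)[C@H]4CCOC4)c(Cl)c3C2=O)c(=O)[nH]1`, has not yet been measured. Compared with compound 2 it carries oxolan-3-yl in place of methyl on a saturated chain carbon bound to an aromatic carbon and a saturated chain carbon. Among the compounds with values here, no measured pair of compounds differs in just one place, so there is no directly comparable step to lean on. Given that, the step from compound 2 to compound 4 is expected to be small, probably not beyond the scatter, in either direction, since the change adds a ring with one hydrogen-bond acceptor but also more carbon. In this assay compound 4 is estimated to give 120000 nM, within a range from 45000 nM to 320000 nM, corresponding to an expected step of a 1.2-fold lower number from compound 2 to compound 4 (0.08 log units; within the scatter).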

Compound 4, solubility: 570000 nM
Compound 4: the middle estimate sits 4.8-fold (0.68 log units) below what was measured; measured number above the stated range.
By their numbers in this assay, from the lowest: compounds 2 and 3 (each within the scatter of the next); then compound 4.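

In this assay, the saturated chain carbon bound to an aromatic carbon and a saturated chain carbon proves sensitive to what it carries: oxolan-3-yl in place of methyl gives a 4.0-fold higher number from compound 2 to compound 4 (0.60 log units; beyond the scatter) and so moves beyond the scatter. This is the first change in a single place among the compounds shown, so it gives the first direct reading of this position, and here the larger group with a ring goes with the higher number. Nothing shown accounts for the size of this step.

The compounds shown leave open whether the higher number goes with the ring itself or with its oxygen, a question that a cyclopentyl group in the same place would help to separate. Also open, from the compounds shown here alone, is whether the opposite arrangement at the new stereocentre would give a similar number.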